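Replacing 4-hydroxyphenyl with 2,3-dichlorophenyl on a shared core

The source may hold more compounds than are shown below. What is called first, only, known or untested is meant among the compounds shown, and "the series" means these compounds.

Values in a functional assay on SW-620 cells (Homo sapiens) for cytotoxicity, read by MTT assay, with a stated time of 72 h; a higher number here means a weaker inhibitor, a lower number a stronger inhibitor:
- Compound 1 `COc1ccc(/C=C2\CCC/C(=C\c3cccc(Cl)c3)C2=O)cc1OC`: 5100 nM
- Compound 2 `COc1ccc(/C=C2\CCC/C(=C\c3ccc(OC)c(OC)c3)C2=O)cc1`: 6600 nM
- Compound 3 `COc1ccc(/C=C2\CCC/C(=C\c3ccc(O)cc3)C2=O)cc1OC`: 7700 nM

Compound 3 stands within the scatter of both other compounds. The steps to it are small: a 1.5-fold higher number from compound 1 to compound 3 (0.18 log units; within the scatter), and a 1.2-fold higher number from compound 2 to compound 3 (0.07 log units; within the scatter). Compound 4 `COc1ccc(/C=C2\CCC/C(=C\c3cccc(Cl)c3Cl)C2=O)cc1OC` carries one change, (2,3-dichlorophenyl in place of 4-hydroxyphenyl on a double-bonded chain carbon bound to a double-bonded ring carbon). The closest measured exchange links 4-hydroxyphenyl and 3-chlorophenyl at that place, and it stayed within the scatter. The remaining step, a 1.3-fold higher number from compound 1 to compound 2 (0.11 log units; within the scatter), did too. No step beyond the scatter is therefore expected in this assay. The expected step is a 1.5-fold lower number from compound 3 to compound 4 (0.19 log units; within the scatter). For compound 4 the estimated value is 5000 nM, with an expected range of 2500 nM to 10000 nM.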

Compound 4, half-maximal inhibitory concentration: 10800 nM
Estimate against measurement, compound 4: 2.2-fold (0.33 log units) below; the measured number lies above the stated range.
By their numbers in this assay, from the lowest: compounds 1, 2, 3 and 4 (each within the scatter of the next, the first and the last beyond it).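

In this assay, the exchange at this place on a double-bonded chain carbon bound to a double-bonded ring carbon produced its first step beyond the scatter when chloro replaced hydrogen on an aromatic carbon, a 2.1-fold higher number from compound 1 to compound 4 (0.33 log units; beyond the scatter). The 2,3-dichlorophenyl group stayed within the scatter of the two oxygen-bearing aryl groups, a 1.4-fold higher number from compound 3 to compound 4 (0.15 log units; within the scatter) and a 1.6-fold higher number from compound 2 to compound 4 (0.21 log units; within the scatter). No measurement here explains the modest step. The compounds shown leave open how an amine or a carboxylic acid on this aromatic ring would fare in this assay.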